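Series notes: ethyl homologue of compound 2

The source may report more compounds than this note shows. Statements on the series, on what has been measured and on what is new or still open speak of the compounds shown alone.

Among the measured compounds shown here, compound 2 `Cc1cccc(NS(=O)(=O)c2ccc(N3CCNC3=O)cc2)c1` holds the lowest of the two numbers measured so far in a functional assay on HT-29 cells (Homo sapiens) for antiproliferative activity, read by sulforhodamine B assay, with a stated time of 48 h; on this read-out higher numbers stand for weaker inhibition and lower numbers for stronger inhibition; compound 2 gives 110 nM. The nearest neighbour is compound 1 `COc1ccc(NS(=O)(=O)c2ccc(N3CCNC3=O)cc2)cc1`, which in this assay gives 800 nM. The step of a 7.3-fold lower number from compound 1 to compound 2 (0.86 log units; beyond the scatter) lies beyond the scatter and is 3-methylphenyl in place of 4-methoxyphenyl on a sulfonamide nitrogen. Compound 3 `CCc1cccc(NS(=O)(=O)c2ccc(N3CCNC3=O)cc2)c1` is not yet measured. The change from compound 2 to compound 3 is methyl in place of hydrogen on a saturated chain carbon bound to an aromatic carbon. Read one bond further out, it is methyl to ethyl, 3-methylphenyl to 3-ethylphenyl. For the measured compounds named here, the single measured step concerns a different change and does not bear on this one; no measured pair shows what the entering methyl does on this chain carbon. The expected step is therefore none beyond the scatter, written as no change at the digits printed from compound 2 to compound 3 (within the scatter). Compound 3 is estimated in this assay at 110 nM, with a range of 40 nM to 300 nM.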

Compound 3, half-maximal inhibitory concentration: 110 nM
Compound 3: middle estimate and measured number agree at the digits printed; the measured number falls inside the stated range.
By their numbers in this assay, from the lowest: compounds 2 and 3 (each within the scatter of the next); then compound 1.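

In this assay, methyl in place of hydrogen on a saturated chain carbon bound to an aromatic carbon gives no change at the digits printed from compound 2 to compound 3 (within the scatter), so compound 2 and compound 3 cannot be told apart on this read-out. Among the compounds shown here, the 3-ethylphenyl group in place of 4-methoxyphenyl on a sulfonamide nitrogen gives a 7.3-fold lower number from compound 1 to compound 3 (0.86 log units; beyond the scatter), a step of the same printed size as the one to the 3-methylphenyl compound, so the gap to compound 1 now holds for two chain lengths. No measurement at hand offers an explanation for either step.

On these data alone, whether a longer chain, such as propyl, or an amine or a carboxylic acid on this chain carbon would keep the number within the scatter stays open. Compound 1 also leaves unresolved how much of its gap belongs to the methoxy group and how much to where it sits, which 3-methoxyphenyl would address.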